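A few compounds are considered here, and "the series" means these few. Any claim that something is new, unique, unknown or untested is made for them only; others in the source may bear on it.

In a functional assay on ECa-109 cells (Homo sapiens) for cytotoxicity, read by MTT assay, with a stated time of 72 h (on this read-out lower numbers stand for stronger inhibition and higher numbers for weaker inhibition), compound 2 `O=C1C(=Cc2ccc(Br)cc2)C(=O)N(c2ccc(Cl)cc2)N1c1ccc(Cl)cc1` gives 12300 nM and compound 3 `COc1cccc(C=C2C(=O)N(c3ccc(Cl)cc3)N(c3ccc(Cl)cc3)C2=O)c1O` gives 39000 nM, the higher of these two numbers, with a step of a 3.2-fold higher number from compound 2 to compound 3 (0.50 log units; beyond the scatter). Compound 1 `CN(C)c1ccc(C=C2C(=O)N(c3ccc(Cl)cc3)N(c3ccc(Cl)cc3)C2=O)cc1` gives only a limit, > 128000 nM. Compound 4 `COc1ccc(C=C2C(=O)N(c3ccc(Cl)cc3)N(c3ccc(Cl)cc3)C2=O)cc1` has 4-methoxyphenyl in place of the 2-hydroxy-3-methoxyphenyl of compound 3: 4-methoxyphenyl in place of 2-hydroxy-3-methoxyphenyl on a double-bonded chain carbon bound to a double-bonded ring carbon. Two measured changes at this place bear on it, the modest 3.2-fold higher number from compound 2 to compound 3 (0.50 log units; beyond the scatter) and the at least modest an at least 3.2-fold lower number from compound 1 to compound 3 (0.51 log units; beyond the scatter). The 4-substituted pair spans a large gap, an at least 10-fold lower number from compound 1 to compound 2 (1.01 log units; beyond the scatter), so compound 4 could fall on either side of compound 3. The expected change, a 1.2-fold higher number from compound 3 to compound 4 (0.09 log units; within the scatter), stays within the scatter, tilted slightly upward. For compound 4 the estimated value is 48000 nM, with an expected range of 15000 nM to 120000 nM.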

Compound 4, half-maximal inhibitory concentration: > 128000 nM
Compound 4 gave a limit, no number (the forecaster's own chance of this, stated with the estimate: 20%); at least 2.6-fold (0.42 log units) between middle value and limit.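

In this assay, 4-methoxyphenyl at this place does not keep up with either group that gave a number: the data show an at least 3.2-fold higher number from compound 3 to compound 4 (0.51 log units; beyond the scatter) and an at least 10-fold higher number from compound 2 to compound 4 (1.01 log units; beyond the scatter). Among the 4-substituted phenyl groups shown, only 4-bromophenyl now gives a number, and the step between compound 1 and compound 4 cannot be read. Compound 4 joins compound 1 at a limit of the assay, not a number: the limit of > 128000 nM in this assay, at which 2 of the 4 values shown sit.

The compounds shown leave open whether a 2-hydroxyphenyl group alone would match compound 3. They also leave open whether chloro or fluoro in place of bromo would match compound 2.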